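The source may hold more compounds than are shown below. What is called first, only, known or untested is meant among the compounds shown, and "the series" means these compounds.

Measured so far:
Compound 1 `COc1ccc(-c2cc(=O)c3cc(CCl)ccc3o2)cc1` gives 32.2% in a functional assay on the whole organism (strain Wistar albino) for inhibition, with Rattus norvegicus as the target, read by paw edema, with stated times of 30 min and 2 h, at a dose of 20 mg/kg by the oral route; on this read-out lower numbers stand for less inhibition and higher numbers for more inhibition at the one dose given (going by the name of the read-out).
Compound 2 `NS(=O)(=O)c1ccc(NCc2ccc3oc(-c4ccccc4Cl)cc(=O)c3c2)cc1` gives 32.2% in this assay.

Compound 2 stands level with compound 1 on these numbers: in this assay compound 2 gives 32.2% and compound 1 gives 32.2%, and that gap lies within the scatter, so no order between them can be read. The step to the unmeasured compound 3 `COc1ccc(-c2cc(=O)c3cc(CNc4ccc(S(N)(=O)=O)cc4)ccc3o2)cc1` is this: 4-methoxyphenyl in place of 2-chlorophenyl on an aromatic carbon. Within the data shown here, no step between measured compounds is available to guide this change, so no direction beyond the scatter is expected, and the 4-methoxyphenyl group is already present in compound 1, whose value is level with that of compound 2. The expected step is a number 0.2 percentage points lower from compound 2 to compound 3 (within the scatter), which is no change beyond the scatter. Compound 3 is therefore estimated at 32%, with a range from 20% to 45%, in this assay.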

Compound 3, a percentage reported as inhibition, in the whole organism at one dose (the size of the read-out at that dose, not a potency): 25.3%
Compound 3: the middle estimate sits 6.7 percentage points above what was measured, within the range that was stated.
By their numbers in this assay, from the lowest: compounds 3, 1 and 2 (each within the scatter of the next).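

Among these compounds, this is the first step between two compounds that differ in one place: in this assay, 4-methoxyphenyl in place of 2-chlorophenyl on the aromatic carbon next to the ring oxygen gives a number 6.9 percentage points lower from compound 2 to compound 3 (within the scatter). At the one dose tested, this position therefore accepts the exchange of one substituted phenyl group for the other without a change beyond the scatter. No measurement is available that could explain the size of this step.

On these data alone, it remains open whether a group of another kind at this position, such as an amine, a carboxylic acid or an unsubstituted phenyl, would move the read-out beyond the scatter. As far as these compounds go, it is also open whether a longer chain in place of the methoxy group on the phenyl ring would leave the read-out unchanged.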